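Isopropyl on the Ring Nitrogen of the Pyrazolopyrimidine Core

The compounds below may be only part of what the source reports. "The series", "measured", "known", "first", "only" and "open" are said of these compounds alone.

Measured compounds:
compound 1 `Cc1cc(Nc2nc(NCc3ccccc3Br)nc3[nH]ncc23)n[nH]1` gives 3990 nM
compound 2 `Cc1cc(Nc2nc(NCc3cccc(Cl)c3)nc3[nH]ncc23)n[nH]1` gives 6860 nM
compound 3 `Cc1cc(Nc2nc(NCc3ccc(F)cc3F)nc3[nH]ncc23)n[nH]1` gives 2670 nM

All three were tested in a functional assay on MDA-MB-231 cells (Homo sapiens) for inhibition, read by MTT assay, with a stated time of 5 days; a lower number here means a stronger inhibitor, a higher number a weaker inhibitor. Compound 3 has the lowest of the three numbers, but the step of a 1.5-fold lower number from compound 1 to compound 3 (0.17 log units; within the scatter) is within the scatter, so compound 3 and compound 1 cannot be ordered. For the measured compounds named here, only the step of a 2.6-fold lower number from compound 2 to compound 3 (0.41 log units; beyond the scatter) is beyond the scatter, and the step of a 1.7-fold higher number from compound 1 to compound 2 (0.24 log units; within the scatter) is not.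

Compound 4 `Cc1cc(Nc2nc(NCc3ccc(F)cc3F)nc3c2cnn3C(C)C)n[nH]1` has not yet been measured. It differs from compound 3 in one place: isopropyl in place of hydrogen on an aromatic nitrogen. Every measured step swaps the aryl group on the saturated chain carbon bound to a nitrogen on an aromatic ring; none alters the aromatic nitrogen of the five-membered ring that is changed here. Going by the values given here, no measured step therefore bears on this change, and the expectation rests on compound 3 alone. Among the compounds with values here, the expected step of a 1.3-fold higher number from compound 3 to compound 4 (0.12 log units; within the scatter) is none beyond the scatter, and the range is set wide because the data give no step of this kind. Compound 4 is expected to give about 3500 nM in this assay, with a range from 900 nM to 15000 nM.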

Compound 4, half-maximal inhibitory concentration: 5350 nM
For compound 4 the middle estimate is 1.5-fold (0.18 log units) below the measured one; the range from low to high includes it.
By their numbers in this assay, from the lowest: compounds 3, 1, 4 and 2 (each within the scatter of the next, the first and the last beyond it).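

For the compounds shown here, the earlier compounds changed only the aryl group on the chain carbon, so this is the first reading at the aromatic nitrogen of the five-membered ring. In this assay, isopropyl in place of hydrogen on that nitrogen gives a 2.0-fold higher number from compound 3 to compound 4 (0.30 log units; within the scatter), so the two compounds cannot be ordered, and this single pair shows no measurable change when the hydrogen gives way to isopropyl, with its 3 heavy atoms. No supporting measurement is available to explain this outcome, and the cell read-out alone cannot say how the substitution acts.

The compounds shown leave open whether other groups on this nitrogen, such as methyl, a longer chain, a cyclopentyl ring or a chain ending in an amine or a carboxylic acid, would move the number beyond the scatter. Going by these compounds alone, they also leave open whether isopropyl on this nitrogen would give a similar result with 2-bromophenyl or 3-chlorophenyl in place of 2,4-difluorophenyl, since this change is seen only with 2,4-difluorophenyl.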